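Trifluoromethoxy in Place of Fluoro: An Expected Inhibition

The source may report more compounds than this note shows. Statements on the series, on what has been measured and on what is new or still open speak of the compounds shown alone.

Of the compounds shown here, three sharing one core have been measured in an assay on isolated protein for inhibition of DNA topoisomerase 1 (Homo sapiens), with a stated time of 30 min, tested at 100 uM; a lower number here means a weaker effect, a higher number a stronger effect of the compound at the concentration tested. Compound 1 `Cc1cccc(-c2nc3ccc(C)cc3c(=O)[nH]2)c1` gives 75.7%. Compound 2 `O=c1[nH]c(-c2cccc3ccccc23)nc2ccc(N3CCCCC3)cc12` gives 100% in this assay, the highest of the three numbers. Compound 3 `Cc1ccc2c(=O)[nH]c(-c3cccc(F)c3)nc2c1` gives 77.5%, the second highest; its nearest neighbour is compound 1, whose number lies within the scatter of it, while compound 2 stands beyond the scatter above it.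

Compound 4 `Cc1ccc2c(=O)[nH]c(-c3cccc(OC(F)(F)F)c3)nc2c1` has not yet been measured. It differs from compound 3 in one place: trifluoromethoxy in place of fluoro on an aromatic carbon. Among the measured compounds shown here, no step between two measured compounds in this set isolates a change of this kind, so nothing measured here tells how large such a swap is. On that basis the step is expected to stay within the scatter, in no certain direction, and the estimate for compound 4 is 78%, between 60% and 93%, which means an expected step of a number 0.5 percentage points higher from compound 3 to compound 4 (within the scatter).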

Compound 4, a percentage reported as inhibition, at one concentration (the size of the read-out at that concentration, not a potency): 77.2%
The estimate for compound 4 lay 0.8 percentage points above the measured number; the measured number falls inside the stated range.
By their numbers in this assay, from the lowest: compounds 1, 4 and 3 (each within the scatter of the next); then compound 2.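

In this assay, among the compounds shown here, the change from fluoro to trifluoromethoxy on an aromatic carbon meta to a large group amounts to a number 0.3 percentage points lower from compound 3 to compound 4 (within the scatter) and is the first step in this set that isolates such a swap. It shows that this position takes trifluoromethoxy, with more heavy atoms and a hydrogen-bond acceptor that fluoro lacks, with no readable change in inhibition at the concentration tested. Nothing at hand offers an explanation for why the two groups read alike.

As far as these compounds go, whether this position responds to any change stays open, since an amine, a carboxylic acid or a longer alkoxy chain on the same carbon could read differently. A single concentration also leaves open whether a true potency would separate compound 3 and compound 4.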